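The source may hold more compounds than are shown below. What is called first, only, known or untested is meant among the compounds shown, and "the series" means these compounds.

Measured compounds:
compound 1, `Cc1cc(C)cc(NC(=O)COc2cc(C)nc3ccc(OCc4ccccc4)cc23)c1`; in a physicochemical assay for lipophilicity, read by HPLC, in phosphate buffer, measured as chromatographic lipophilicity, at pH 7.4 (a lower number here means a more polar compound, a higher number a more lipophilic compound), compound 1 gives 7.03
compound 2, `COc1ccc2nc(C)cc(NC(=O)C(=O)Nc3cc(C)cc(C)c3)c2c1`; compound 2 gives 6.47
compound 3, `COc1ccc2nc(C)cc(OCC(=O)Nc3cccc(C)c3)c2c1`; compound 3 gives 4.83

Compound 3 thus stands lowest of the three numbers in this assay; the nearest to it is compound 2, whose number is higher by a gap beyond the scatter, and the furthest is compound 1, higher still by a gap also beyond the scatter. Compound 4, `COc1ccc2nc(C)cc(OCC(=O)NNC(=O)c3ccncc3)c2c1`, has not yet been measured in this assay. Set against compound 3 it carries ((pyridin-4-yl)carbonyl)amino in place of 3-methylphenyl on an amide-type nitrogen. Within the data shown here, no step between two measured compounds matches this change, so nothing in the measured set fixes its size directly. A downward step beyond the scatter is nonetheless expected, a number 2.53 log units lower from compound 3 to compound 4 (beyond the scatter). Compound 4 is estimated at 2.3, with a range from 1.3 to 3.3.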

Compound 4, distribution coefficient: 1.48
For compound 4 the middle estimate is 0.82 log units above the measured one, and the stated range covers the measured number.
By their numbers in this assay, from the lowest: compound 4; then compound 3; then compound 2; then compound 1.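

In this assay, among these compounds, ((pyridin-4-yl)carbonyl)amino in place of 3-methylphenyl on an amide-type nitrogen gives a number 3.35 log units lower from compound 3 to compound 4 (beyond the scatter), the only step read at this position, and a large one. Among the compounds shown here, the change brings in a ring hetero atom, a carbonyl, and hydrogen-bond donor and acceptors together, so the single step cannot be divided among them. Nothing measured here accounts for its size. A benzoylamino group or a pyridin-4-yl group at the same place would be needed to separate the ring nitrogen's share from that of the carbonyl and amino link.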